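Inverting One Ring Stereocentre of Compound 1

The source may report more compounds than this note shows. Statements on the series, on what has been measured and on what is new or still open speak of the compounds shown alone.

Compound 1 `[N-]=[N+]=NC[C@H]1NC[C@@H](O)[C@H]1O` was tested in an assay on isolated protein for inhibition of alpha-galactosidase (Coffea arabica), with stated times of 5 min and 20 min, tested at 1 mM (on this read-out lower numbers stand for less inhibition and higher numbers for more inhibition at the one concentration tested (going by the name of the read-out)), and gives 88%. Among the measured compounds shown here, this is the only plain number reported in this assay so far. Compound 2 `O[C@@H]1[C@H](O)CN[C@@H]1Cn1cc(-c2ccccc2)nn1` is reported in this assay only as a limit of the assay, <= 50%. What is known therefore rests on (the limit of <= 50% in this assay, at which 1 of the 2 values shown sits), with compound 1 standing clearly above that limit.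

Compound 3 `[N-]=[N+]=NC[C@@H]1NC[C@@H](O)[C@H]1O` has not yet been measured. It differs from compound 1 as follows: the two compounds have the same atoms and bonds; at least one stereo element is drawn with a configuration in one of them and without one in the other: 1 of 4 stereo elements differ; a stereocentre at a saturated ring carbon is drawn R in compound 1 and S in compound 3. For the measured compounds named here, no pair of measured compounds differs in one place, so there is no measured step in this set to lean on. The expected step from compound 1 to compound 3 is a number 33 percentage points lower from compound 1 to compound 3 (beyond the scatter), downward and larger than the scatter, though with wide uncertainty. Compound 3 is accordingly estimated at 55%, within a range from 20% to 88%, with a real chance that only a limit is reported.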

Compound 3, a percentage reported as inhibition, at one concentration (the size of the read-out at that concentration, not a potency): 44%
Compound 3: middle estimate off by 11 percentage points, on the high side; low and high end bracket the measured number.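

Inverting a single saturated ring carbon, with atoms and bonds unchanged, gives a number 44 percentage points lower from compound 1 to compound 3 (beyond the scatter) in this assay. Among the compounds shown here, this is the first step in the set that isolates one change, and it shows that the configuration at this ring carbon, drawn R in compound 1 and S in compound 3, matters on its own for this read-out at the one concentration tested. One caveat applies to how sharply that configuration can be read from the structures as drawn: the fact that one of compounds 1 and 3 is drawn with a defined configuration and the other without, at the place where they differ

Going by these compounds, it remains open whether inverting the other ring stereocentres would have an effect of similar size, and how far this step reflects a change in potency, which a single concentration cannot tell. Also open, on these data alone, is whether the same inversion would matter as much with a primary amine in place of the azide.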